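Methoxy in place of chloro on the benzyl arm

The source may report more compounds than this note shows. Statements on the series, on what has been measured and on what is new or still open speak of the compounds shown alone.

Compound 3 `O=C(CCCCCn1cc(Nc2ncc3ccn(Cc4cccc(Cl)c4)c3n2)cn1)NO` gives 34.4 nM in an assay on isolated protein for inhibition of protein deacetylase HDAC6 (Homo sapiens), with a stated time of 60 min (a lower number here means a stronger inhibitor, a higher number a weaker inhibitor), the highest number among the three measured compounds. Compound 2 `O=C(CCCCCn1cc(Nc2ncc3ccn(Cc4ccccc4)c3n2)cn1)NO` gives 13.8 nM, and compound 1 `CS(=O)(=O)c1ccc(-n2ccc3cnc(Nc4cnn(CCCCCC(=O)NO)c4)nc32)cc1` gives 10.8 nM. The step of a 2.5-fold higher number from compound 2 to compound 3 (0.40 log units; beyond the scatter) is modest, as is the step of a 3.2-fold higher number from compound 1 to compound 3 (0.50 log units; beyond the scatter), while the step of a 1.3-fold higher number from compound 1 to compound 2 (0.11 log units; within the scatter) stays within the scatter. Compound 4 `COc1cccc(Cn2ccc3cnc(Nc4cnn(CCCCCC(=O)NO)c4)nc32)c1` differs from compound 3 in one place: methoxy in place of chloro on an aromatic carbon. Among the measured compounds shown here, no measured step tests a methoxy group at that place; the only comparison bearing on it is a 2.5-fold higher number from compound 2 to compound 3 (0.40 log units; beyond the scatter), which shows that a substituent there can shift this assay modestly. The step of a 1.6-fold lower number from compound 3 to compound 4 (0.19 log units; within the scatter) is therefore expected to be small, in either direction. Compound 4 is estimated at 22 nM, with a range from 8 nM to 60 nM.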

Compound 4, half-maximal inhibitory concentration: 37.6 nM
Compound 4: the middle estimate sits 1.7-fold (0.23 log units) below what was measured; the range from low to high includes it.
By their numbers in this assay, from the lowest: compounds 1 and 2 (each within the scatter of the next); then compounds 3 and 4 (each within the scatter of the next).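

In this assay, methoxy and chloro on this aromatic carbon cannot be told apart (a 1.1-fold higher number from compound 3 to compound 4 (0.04 log units; within the scatter)). Methoxy in place of hydrogen gives a modest step (a 2.7-fold higher number from compound 2 to compound 4 (0.44 log units; beyond the scatter)), as does 3-methoxybenzyl in place of 4-(methylsulfonyl)phenyl (a 3.5-fold higher number from compound 1 to compound 4 (0.54 log units; beyond the scatter)), so two different substituents at this place now go with a modest rise over the plain benzyl arm. No available evidence accounts for this shared result.

As far as these compounds go, whether an amine, a carboxylic acid or a longer ether chain at this place would read the same remains open.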